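Cyclobutyl for Oxolanyl on the Methyl-Bearing Core

The source may report more compounds than this note shows. Statements on the series, on what has been measured and on what is new or still open speak of the compounds shown alone.

Compound 1 `CCCn1c(-c2ccccc2)nc2c(NC3CCC3)ncnc21`: 264 nM
Compound 2 `CCCn1c(-c2ccccc2)nc2c(NC3CCOC3)ncnc21`: 2810 nM
Compound 3 `Cn1c(-c2ccccc2)nc2c(NC3CCOC3)ncnc21`: 6260 nM

Of the compounds shown here, three have been tested in an assay on CHO cells for displacement of a labelled ligand from adenosine receptor A3 (Homo sapiens), read by scintillation counting, with a stated time of 3 h; on this read-out higher numbers stand for weaker inhibition and lower numbers for stronger inhibition. Compound 2 and compound 1 share a core and differ by cyclobutyl in place of oxolan-3-yl on a nitrogen on an aromatic ring; this change gave an 11-fold lower number from compound 2 to compound 1 (1.03 log units; beyond the scatter). Compound 2 and compound 3 differ in their cores by hydrogen in place of ethyl on a saturated chain carbon bound to an aromatic nitrogen, which gave a 2.2-fold higher number from compound 2 to compound 3 (0.35 log units; beyond the scatter). Compound 3 thus stands with the highest number of the three.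

Compound 4 `Cn1c(-c2ccccc2)nc2c(NC3CCC3)ncnc21` has not yet been tested. It differs from compound 3 by cyclobutyl in place of oxolan-3-yl on a nitrogen on an aromatic ring, and the surroundings of the place are the same as in the pair of compound 2 and compound 1, so this is the same change carried onto the core of compound 3. If it acts as it did there, the step of an 11-fold lower number from compound 2 to compound 1 (1.03 log units; beyond the scatter) would be repeated, and the expected step is an 11-fold lower number from compound 3 to compound 4 (1.03 log units; beyond the scatter) in this assay. On that basis compound 4 is estimated at 580 nM, with a likely range from 250 nM to 1400 nM.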

Compound 4, inhibition constant: 280 nM
For compound 4 the middle estimate is 2.1-fold (0.32 log units) above the measured one; measured number inside the range.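

In this assay, cyclobutyl in place of oxolan-3-yl gave a 22-fold lower number from compound 3 to compound 4 (1.35 log units; beyond the scatter), and this step agrees with the earlier one on the other core: the same change on two cores in this assay, an 11-fold lower number (1.03 log units; beyond the scatter) from compound 2 to compound 1 and a 22-fold lower number (1.35 log units; beyond the scatter) from compound 3 to compound 4, 2.1-fold (0.32 log units) apart, within the scatter of two such steps. The second change, hydrogen in place of ethyl on a saturated chain carbon bound to an aromatic nitrogen, gave a 1.1-fold higher number from compound 1 to compound 4 (0.03 log units; within the scatter), and its two steps also agree: the same change on two cores in this assay, a 2.2-fold higher number (0.35 log units; beyond the scatter) from compound 2 to compound 3 and a 1.1-fold higher number (0.03 log units; within the scatter) from compound 1 to compound 4, 2.1-fold (0.32 log units) apart, within the scatter of two such steps. Together these show that each change carried over between the two cores in this set of four compounds, but they do not show that either would carry over to a core outside it, and they give no reason for the size of either step.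

The compounds shown leave open whether other groups in the same place on the nitrogen, such as cyclopentyl or isopropyl, would follow the cyclobutyl step. They also leave open whether a longer chain on the aromatic nitrogen, such as butyl, would alter that step.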